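Tert-butyl in place of trifluoromethyl: expectation for compound 3

This account rests on a few compounds, and the source may have more. Where it says the series, first, only, none or still open, it means among the compounds named here.

Among the measured compounds shown here, compound 2 `Cn1ncc2c(NC(=O)NCc3cc(C(F)(F)F)nn3-c3ccc(C(F)(F)F)cc3)cccc21` gives 3.9 nM in an assay on CHO-K1 cells for antagonist activity at transient receptor potential cation channel subfamily V member 1 (Homo sapiens), read by FLIPR and calcium flux, with a stated time of 6 min; on this read-out lower numbers stand for stronger inhibition and higher numbers for weaker inhibition; compound 1 `Cn1ncc2c(NC(=O)NCc3cc(C(F)(F)F)nn3-c3cccc(Cl)c3)cccc21` gives 2.3 nM, and the pair sit within the scatter of each other, the only step so far being a 1.7-fold higher number from compound 1 to compound 2 (0.23 log units; within the scatter). Compound 3 `Cn1ncc2c(NC(=O)NCc3cc(C(F)(F)F)nn3-c3ccc(C(C)(C)C)cc3)cccc21` carries tert-butyl in place of trifluoromethyl on an aromatic carbon. That one measured step, which exchanges the aryl group on the aromatic nitrogen, is the only one bearing on this region, and it is small. For the measured compounds named here, no step tests tert-butyl against trifluoromethyl directly. For compound 3 the expected step in this assay is therefore a 1.2-fold higher number from compound 2 to compound 3 (0.06 log units; within the scatter), nothing beyond the scatter. The estimate for compound 3 is 4.5 nM, range 1.5 nM to 14 nM.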

Compound 3, inhibition constant: 13.2 nM
Estimate against measurement, compound 3: 2.9-fold (0.47 log units) below; the range from low to high includes it.
By their numbers in this assay, from the lowest: compounds 1 and 2 (each within the scatter of the next); then compound 3.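

In this assay, among the compounds shown here, this position proves sensitive to tert-butyl in place of trifluoromethyl, which gives a 3.4-fold higher number from compound 2 to compound 3 (0.53 log units; beyond the scatter) and is the first step beyond the scatter. The aryl group on the aromatic nitrogen therefore does not tolerate every exchange: a 5.7-fold higher number from compound 1 to compound 3 (0.76 log units; beyond the scatter) also lies beyond the scatter, whereas the step between compounds 1 and 2 does not. No measurement at hand accounts for this difference. On these data alone, whether methyl, methoxy or an amine on that aromatic carbon would stay within the scatter of compound 2 remains open.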